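A few compounds are considered here, and "the series" means these few. Any claim that something is new, unique, unknown or untested is made for them only; others in the source may bear on it.

Compound 1 `CCN(c1ccc(C#N)c(Cl)c1)c1cc(-c2ccncc2)ccc1C` is the point of reference for the series. For the measured compounds named here, in an ADME assay on L02 cells (Homo sapiens) for antiproliferative activity, read by CCK-8 assay, with a stated time of 6 days (a lower number here means a stronger inhibitor, a higher number a weaker inhibitor), compound 1 gives 1730 nM, and this is the only number in hand: compound 2 `N#Cc1ccc(N2CCc3cc(-c4ccncc4)ccc3C2)cc1C(F)(F)F` is described as "not determined" (no result reported) in this assay, so nothing can be said about how it stands next to compound 1, and no step between two measured compounds is available. Compound 1 therefore stands alone on the numbers shown, neither strong nor weak by comparison within this set.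

Compound 3 `CCN(c1ccc(C#N)c(Cl)c1)c1cc(-c2cccnc2)ccc1C` differs from compound 1 in one place: pyridin-3-yl in place of pyridin-4-yl on an aromatic carbon. Without any measured step to lean on, the size of the move is expected to stay within the usual scatter of this assay, with no clear direction. The step expected is a 1.2-fold higher number from compound 1 to compound 3 (0.06 log units; within the scatter). Compound 3 is accordingly estimated at 2000 nM in this assay, with a range from 700 nM to 6000 nM.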

Compound 3, half-maximal inhibitory concentration: 12700 nM
Beside the measured number, compound 3's estimate is 6.4-fold (0.80 log units) below it; measured number above the stated range.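

Where the ring nitrogen sits matters at this position: with the atom count unchanged, pyridin-3-yl in place of pyridin-4-yl in this assay gives a 7.3-fold higher number from compound 1 to compound 3 (0.87 log units; beyond the scatter), which makes compound 3 the weaker inhibitor of the pair. The carbon meta to a large group and para to a methyl group therefore distinguishes two groups with identical counts of heavy atoms, donors and acceptors, and the pyridin-4-yl group is the better of the two seen here. No measurement at hand bears on the origin of this step.

As far as these compounds go, it remains open whether pyridin-2-yl or an unsubstituted phenyl ring at this carbon would read closer to compound 1 or to compound 3. A single pair also cannot show whether an amine on the pyridine ring, or the same nitrogen shift on another core, would follow this direction.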